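The source may report more compounds than this note shows. Statements on the series, on what has been measured and on what is new or still open speak of the compounds shown alone.

Working notes on the series. Among the compounds with values here, in a functional assay on WiDr cells (Homo sapiens) for inhibition (a higher number here means a weaker inhibitor, a lower number a stronger inhibitor), compound 1 (`N#CC1CN1C(=O)Nc1ccc(F)cc1`) gives 9000 nM and holds the only true number so far. Compound 2 (`N#CC1CN1C(N)=O`) reads > 280000 nM in the same measurement, and this is a limit and not a number. Compound 2 carries no aromatic ring, while compound 1 does.

The next analogue is compound 3 (`N#CC1CN1C(=O)Nc1ccc(C(F)(F)F)cc1`), which keeps the core of compound 1 and places trifluoromethyl in place of fluoro on an aromatic carbon, para to a group of 8 heavy atoms (trifluoromethyl in place of fluoro on an aromatic carbon). Within the data shown here, no pair of measured compounds shows what a swap of this kind does. The expectation therefore rests on compound 1 at 9000 nM as the single anchor, with the aromatic ring retained. In this assay a small move toward stronger inhibition is expected, near the edge of the usual scatter and with no firm claim on direction. The estimated change a 1.5-fold lower number from compound 1 to compound 3 (0.18 log units; within the scatter) is correspondingly modest. Compound 3 is expected at 6000 nM with an estimated range from 2000 nM to 20000 nM in this read-out.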

Compound 3, half-maximal inhibitory concentration: 5800 nM
The estimate for compound 3 lay 1.0-fold (0.01 log units) above the measured number; low and high end bracket the measured number.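

Within the data shown here, the step of a 1.6-fold lower number from compound 1 to compound 3 (0.19 log units; within the scatter) in this assay is the first measured change at this position, on an aromatic carbon of a six-membered aromatic ring of carbon only, para to a group of 8 heavy atoms. It shows that trifluoromethyl, with 4 heavy atoms, can stand in place of fluoro, with 1 heavy atom, without a change in the read-out that can be told from the scatter, so this one swap gives no direction for the position. Nothing shown on the series bears on why these two groups read alike.

From the compounds shown here alone, what an amine, a carboxylic acid, a methoxy group or a longer chain would do at this same position stays open, as does the reading of the ring with hydrogen there in place of any of these groups. Compound 2 stays at > 280000 nM, which is a limit and not a number, so the size of any contribution from the aromatic ring cannot be read from the compounds shown.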